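Ethyl on the carbamoyl nitrogen of a dithiocarbamate triazole

A few compounds are considered here, and "the series" means these few. Any claim that something is new, unique, unknown or untested is made for them only; others in the source may bear on it.

Compound 1 `CCNC(=O)N1CCN(C(=S)SCc2cn(Cc3ccccc3F)nn2)CC1`: 23700 nM
Compound 2 `Cc1ccc(Cn2cc(CSC(=S)N3CCN(C(N)=O)CC3)nn2)cc1`: > 128000 nM

Of the compounds shown here, two have been measured in a functional assay on EC9706 cells (Homo sapiens) for cytotoxicity, read by MTT assay, with a stated time of 72 h; on this read-out higher numbers stand for weaker inhibition and lower numbers for stronger inhibition. Compound 1 gives 23700 nM in this assay. For compound 2 the result in this assay is only a limit, > 128000 nM, and not a number; this is the limit of > 128000 nM in this assay, at which 1 of the 2 values shown sits. Within the data shown here, compound 1 and compound 2 differ in more than one place, so their two values show only that compound 1 is recorded with a number while compound 2 is recorded at the limit.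

Compound 3 `CCNC(=O)N1CCN(C(=S)SCc2cn(Cc3ccc(C)cc3)nn2)CC1` is not yet measured. It differs from compound 2 by ethyl in place of hydrogen on an amide-type nitrogen. Among the measured compounds shown here, since compound 2 sits at the limit and no measured pair shows this change on its own, the size of the step from compound 2 to compound 3 cannot be taken from measured values; a modest gain is expected, with the limit still possible. The step in this assay is estimated as an at least 1.8-fold lower number from compound 2 to compound 3 (0.26 log units; that floor lies within the scatter). For compound 3 the estimate in this assay is 70000 nM, in a range from 20000 nM to 200000 nM.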

Compound 3, half-maximal inhibitory concentration: > 128000 nM
Compound 3 gave a limit, no number; the forecaster's own chance of this, stated with the estimate: 40%; middle value at least 1.8-fold (0.26 log units) away from the limit.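

In this assay, ethyl in place of hydrogen on the amide-type nitrogen leaves the 4-methylphenyl series at the limit: compound 3 is recorded only as a limit, and the step from hydrogen to ethyl cannot be read. With the ethylcarbamoyl group held constant, the change at the other place, 4-methylphenyl in place of 2-fluorophenyl, gives the first readable step, an at least 5.4-fold higher number from compound 1 to compound 3 (0.73 log units; beyond the scatter), so ethyl alone does not bring a number in this pair. Most of the compounds shown now give no number: the limit of > 128000 nM in this assay, at which 2 of the 3 values shown sit.

On these data alone, what hydrogen on the amide-type nitrogen would do alongside 2-fluorophenyl remains open. Also open, as far as these compounds go, is whether a longer chain on that nitrogen, or an amine or carboxylic acid on the phenyl ring, would bring a 4-methylphenyl compound off the limit.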